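A few compounds are considered here, and "the series" means these few. Any claim that something is new, unique, unknown or untested is made for them only; others in the source may bear on it.

In a functional assay on HL-60 cells (Homo sapiens) for antiproliferative activity, read by MTT assay, with a stated time of 24 h (a lower number here means a stronger inhibitor, a higher number a weaker inhibitor), compound 2 `CCN(CC)CCNc1ccnc(Nc2cc(OC)c(OC)c(OC)c2)n1` reads > 50000 nM. That reading is a limit of the assay and not a number. Compound 3 `CCN(CC)CCNc1nc(Nc2cc(OC)c(OC)c(OC)c2)ncc1I` differs from compound 2 by one change, iodo in place of hydrogen on an aromatic carbon. Among the measured compounds shown here, no measured pair shows this change on its own, so only a modest move toward stronger inhibition is expected. This expectation rests on compound 1 `COc1cc(Nc2ncc(I)c(NCCCN)n2)cc(OC)c1OC`, which also carries iodo and gives 43400 nM. The expected size is an at least 2.0-fold lower number from compound 2 to compound 3 (0.30 log units; that floor lies within the scatter). The estimate for compound 3 is 25000 nM, within an expected range of 8000 nM to 60000 nM.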

Compound 3, half-maximal inhibitory concentration: 21600 nM
Compound 3: middle estimate off by 1.2-fold (0.06 log units), on the high side, and the stated range covers the measured number.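

In this assay, among the compounds shown here, iodo on this aromatic carbon gives an at least 2.3-fold lower number from compound 2 to compound 3 (0.36 log units; beyond the scatter) as the first reading of this change on its own. Compound 2 reads as a limit of the assay and not a number, so the step has only a floor: the limit of > 50000 nM in this assay, at which 1 of the 3 values shown sits. With iodo in place, the two side chains read alike, with diethylamino in place of aminomethyl giving a 2.0-fold lower number from compound 1 to compound 3 (0.30 log units; within the scatter) as the step. Going by these compounds, how bromo or a methyl group on the same carbon would read stays open, and so does the full size of the step from hydrogen to iodo.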